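Hydroxy for nitro on the benzamide ring: toxicity notes

The compounds below may be only part of what the source reports. "The series", "measured", "known", "first", "only" and "open" are said of these compounds alone.

Measured compounds:
compound 1 `COc1ccc(-c2cnc(NC(=O)c3cccc([N+](=O)[O-])c3)n2C)cc1`: > 100000 nM
compound 2 `Cc1ccc(-c2cnc(NC(=O)c3ccc(F)cc3)n2C)cc1`: 60000 nM
compound 3 `CCCn1c(-c2ccc(OC)cc2)cnc1NC(=O)c1ccc(F)cc1`: > 100000 nM

All three values come from a toxicity assay on THP-1 cells (Homo sapiens) for inhibition; on this read-out higher numbers stand for lower toxicity in this test and lower numbers for higher toxicity in this test. For compound 1 the value is a limit of the assay and not a number. For compound 3 the value is likewise a limit. Compound 2 alone gives a number on this read-out. Compound 1 therefore stands at the limit of > 100000 nM in this assay, at which 2 of the 3 values shown sit; where it would lie as a number is not known, only that it sits at this limit.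

Not yet measured is compound 4 `COc1ccc(-c2cnc(NC(=O)c3cccc(O)c3)n2C)cc1`. It differs from compound 1 in one place: hydroxy in place of nitro on an aromatic carbon. Within the data shown here, no step between measured compounds that differ in one place exists in this set, so the size of this change has no direct precedent here.

With compound 1 already at the limit, the step is expected to be none beyond the scatter, and most likely compound 4 will again be reported only as a limit. Compound 4 is expected to give 100000 nM in this assay, with a range from 50000 nM to 200000 nM. The step from compound 1 to compound 4 is thus expected to be a number no higher from compound 1 to compound 4 (the limit leaves the size open).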

Compound 4, half-maximal cytotoxic concentration: > 100000 nM
Compound 4: no number, only a limit; the forecaster's own chance of this, stated with the estimate: 70%; the middle value lies on the limit itself.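

No step can be read from compound 1 to compound 4, since both values are limits and not numbers in this assay: the limit of > 100000 nM in this assay, at which 3 of the 4 values shown sit.

From the compounds shown here alone, whether hydroxy in place of nitro changes the value in this assay at all, and by how much, stays open.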